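Swapping a heptyl chain for a methoxyphenyl amide

The source may hold more compounds than are shown below. What is called first, only, known or untested is meant among the compounds shown, and "the series" means these compounds.

Compound 3 `CCCCCCCCn1cc(COC2(C(F)(F)F)Oc3ccccc3C=C2C(=O)OCC)nn1` stands at the upper limit of a functional assay on MCF7 cells (Homo sapiens) for inhibition, read by MTT assay, with a stated time of 24 h; on this read-out lower numbers stand for stronger inhibition and higher numbers for weaker inhibition; compound 3 gives > 150000 nM, which is a limit and not a number. Compound 1 `CCOC(=O)C1=Cc2ccccc2OC1(OCc1cn(-c2cccc(OC)c2)nn1)C(F)(F)F` likewise gives only a limit, > 150000 nM. Among the compounds with values here, compound 2 `CCOC(=O)C1=Cc2ccccc2OC1(OCc1cn(CC(=O)NC2CCCCC2)nn1)C(F)(F)F` gives 12100 nM, the one numeric value in this assay. The limit (the limit of > 150000 nM in this assay, at which 2 of the 3 values shown sit) thus holds for two of the three. The steps read an at least 12-fold lower number from compound 1 to compound 2 (1.09 log units; beyond the scatter), an at least 12-fold higher number from compound 2 to compound 3 (1.09 log units; beyond the scatter), and a step that the two limits leave unreadable from compound 1 to compound 3. Compound 4 `CCOC(=O)C1=Cc2ccccc2OC1(OCc1cn(CC(=O)Nc2ccc(OC)cc2)nn1)C(F)(F)F` differs from compound 3 by (4-methoxyphenyl)carbamoyl in place of heptyl on a saturated chain carbon bound to an aromatic nitrogen. Because the opposite exchange gave an at least 12-fold higher number from compound 2 to compound 3 (1.09 log units; beyond the scatter), compound 4 is expected to return to a readable number near that of compound 2. Compound 4 is estimated at 15000 nM, in a range from 5000 nM to 60000 nM. That implies an expected step of an at least 10-fold lower number from compound 3 to compound 4 (1.00 log units; beyond the scatter).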

Compound 4, half-maximal inhibitory concentration: 28100 nM
The estimate for compound 4 lay 1.9-fold (0.27 log units) below the measured number; the range from low to high includes it.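

In this assay, a readable number does not depend on the cyclohexyl group, since an aryl amide also gives one, with an at least 5.3-fold lower number from compound 3 to compound 4 (0.72 log units; beyond the scatter) and an at least 5.3-fold lower number from compound 1 to compound 4 (0.72 log units; beyond the scatter). The group on the amide-type nitrogen still matters, with a 2.3-fold higher number from compound 2 to compound 4 (0.37 log units; beyond the scatter), so 4-methoxyphenyl keeps a readable number but does not match cyclohexyl. Compound 1 and compound 3 remain at a limit: the limit of > 150000 nM in this assay, at which 2 of the 4 values shown sit.

From the compounds shown here alone, what a carboxylic acid or a benzyl amide would give on a saturated chain carbon bound to an aromatic nitrogen stays open.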